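Methoxy added to the distal phenyl of compound 2

The source may hold more compounds than are shown below. What is called first, only, known or untested is meant among the compounds shown, and "the series" means these compounds.

compound 1 `O=C(/C=C/c1cccc(O)c1)c1cccc(-n2cc(-c3ccccc3)[nH]c2=O)c1` — 2490 nM
compound 2 `COc1cc(/C=C/C(=O)c2cccc(-n3cc(-c4ccccc4)[nH]c3=O)c2)cc(OC)c1OC` — 1400 nM

In a functional assay on NCI-H460 cells (Homo sapiens) for inhibition (on this read-out lower numbers stand for stronger inhibition of growth and higher numbers for weaker inhibition of growth), compound 2 gives 1400 nM, the lower of the two numbers shown. Compound 1 gives 2490 nM, which lies within the scatter of it, so the two are not separated. Compound 3 `COc1ccc(-c2cn(-c3cccc(C(=O)/C=C/c4cc(OC)c(OC)c(OC)c4)c3)c(=O)[nH]2)cc1` differs from compound 2 by methoxy in place of hydrogen on an aromatic carbon. Going by the values given here, no measured pair carries this change, so its size is unknown from the data. In this assay the step is expected to be a 1.2-fold lower number from compound 2 to compound 3 (0.07 log units; within the scatter), nothing beyond the scatter. Compound 3 is estimated at 1200 nM, with a range from 450 nM to 3200 nM.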

Compound 3, concentration for 50% growth inhibition: 1560 nM
Compound 3: the middle estimate sits 1.3-fold (0.11 log units) below what was measured, and the stated range covers the measured number.
By their numbers in this assay, from the lowest: compounds 2, 3 and 1 (each within the scatter of the next).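

In this assay the change from phenyl to 4-methoxyphenyl gives a 1.1-fold higher number from compound 2 to compound 3 (0.05 log units; within the scatter), the first read at this position, since compound 1 and compound 2 carry the same unsubstituted phenyl there. A methoxy on this aromatic carbon, para to a large group, therefore leaves the number within the scatter. No supporting data bear on this result.

This is a single substituent at a single position. From the compounds shown here alone, whether an amine, a carboxylic acid or a longer chain in the same place would move the number beyond the scatter remains open.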